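Trimming the Oxime Side Chain: Compound 1 to Compound 3

The source may report more compounds than this note shows. Statements on the series, on what has been measured and on what is new or still open speak of the compounds shown alone.

Compound 1, `CCOC(=O)CO/N=C(/c1ccc(OC)c(OC)c1OC)c1cccc2ccccc12`: > 20000 nM
Compound 2, `COc1ccc(C(OCc2ccccc2)c2cccc3ccccc23)c(OC)c1OC`: 14100 nM

In a functional assay on MCF7 cells (Homo sapiens) for inhibition, read by sulforhodamine B assay, with a stated time of 48 h (on this read-out lower numbers stand for stronger inhibition and higher numbers for weaker inhibition), compound 1 reaches only > 20000 nM, which is a limit of the assay and not a measured number. Compound 2 gives 14100 nM in this assay. Compound 3, `COc1ccc(/C(=N/OC(C)=O)c2cccc3ccccc23)c(OC)c1OC`, carries acetyl in place of (ethoxycarbonyl)methyl on an oxygen. With compound 1 sitting at the limit of > 20000 nM in this assay, at which 1 of the 2 values shown sits, the step that the limit leaves unreadable from compound 1 to compound 3 is expected to stay within the usual scatter, with no clear direction. Compound 3 is estimated at 25000 nM, within a range from 8000 nM to 70000 nM, and a limit rather than a number may again be the outcome.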

Compound 3, half-maximal inhibitory concentration: > 20000 nM
Compound 3 was reported as a limit; the forecaster's own chance of this, stated with the estimate: 60%; the middle value lies beyond the limit too.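

In this assay, compound 1 and compound 3 both stand at limits rather than numbers, and the step between them cannot be read. The compounds shown leave open whether acetyl in place of (ethoxycarbonyl)methyl changes inhibition at all.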